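The source may hold more compounds than are shown below. What is called first, only, known or untested is meant among the compounds shown, and "the series" means these compounds.

Measured so far in a functional assay on A2780 cells (Homo sapiens) for antiproliferative activity, read by MTT assay, with a stated time of 48 h; on this read-out higher numbers stand for weaker inhibition and lower numbers for stronger inhibition:
- compound 1 `COc1ccc(-c2cc3c(cn2)[nH]c(=O)n3-c2cc(OC)c(OC)c(OC)c2)cc1F`: 730 nM
- compound 2 `COc1ccc(-c2cc3c(cn2)[nH]c(=O)n3-c2cc(OC)c(OC)c(OC)c2)cc1O`: 240 nM
- compound 3 `COc1ccc(-c2cc3c(cn2)[nH]c(=O)n3-c2cc(OC)c(OC)c(OC)c2)cc1C`: 1530 nM

Compound 1 holds the second highest of the three numbers, lying between compound 2 and compound 3. Its nearest neighbour is compound 3, with a 2.1-fold higher number from compound 1 to compound 3 (0.32 log units; beyond the scatter). Its furthest is compound 2, with a 3.0-fold lower number from compound 1 to compound 2 (0.48 log units; beyond the scatter). The remaining measured step is a 6.4-fold higher number from compound 2 to compound 3 (0.80 log units; beyond the scatter).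

Not yet measured is compound 4 `COc1ccc(-c2cc3c([nH]c(=O)n3-c3cc(OC)c(OC)c(OC)c3)c(C(N)=O)n2)cc1F`. The change from compound 1 is carbamoyl in place of hydrogen on an aromatic carbon of the six-membered aromatic ring with 1 nitrogen, next to the ring nitrogen.

Among the compounds with values here, none of the measured steps bears directly on this change. All three exchange groups on the aromatic carbon that holds the fluoro of compound 1, and none touches the carbon that changes in compound 4. Within the data shown here, they show only that single exchanges have given modest steps so far, and they offer no guide to direction. In this assay no step beyond the scatter can therefore be predicted with any confidence, and a modest step either way remains possible.

The central expectation is a 1.1-fold higher number from compound 1 to compound 4 (0.04 log units; within the scatter). For compound 4 the estimated value is 800 nM, with an expected range of 180 nM to 3500 nM.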

Compound 4, half-maximal inhibitory concentration: 410 nM
For compound 4 the middle estimate is 2.0-fold (0.29 log units) above the measured one; measured number inside the range.
By their numbers in this assay, from the lowest: compounds 2, 4 and 1 (each within the scatter of the next, the first and the last beyond it); then compound 3.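

In this assay carbamoyl in place of hydrogen on the aromatic carbon next to the ring nitrogen gives a 1.8-fold lower number from compound 1 to compound 4 (0.25 log units; within the scatter) and so stays within the scatter. Within the data shown here, this is the first reading at this carbon, since the earlier exchanges all fell on the carbon that holds the fluoro of compound 1. With the 3-fluoro-4-methoxyphenyl group and the rest of the core kept, this position carries an added group of 3 heavy atoms with no change in the antiproliferative read-out beyond the scatter, and nothing measured in the series accounts for this.

A single group at this carbon leaves open how far the outcome depends on the group itself: a carboxylic acid, a nitrile, an aminomethyl group or an N-methyl amide here would test that. Also open, as far as these compounds go, is whether carbamoyl at this carbon gives a similar outcome when hydroxy or methyl replaces the fluoro on the aryl ring, as in the other compounds.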